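A Vinyl Group Added Next to the Sulfonamide

The compounds below may be only part of what the source reports. "The series", "measured", "known", "first", "only" and "open" are said of these compounds alone.

Of the compounds shown here, three sharing a core have been measured in an assay on cells for antagonist activity at transient receptor potential cation channel subfamily V member 1 (Rattus norvegicus), read by scintillation counting, with a stated time of 10 min, in the presence of a further agent that is not named here; on this read-out higher numbers stand for weaker inhibition and lower numbers for stronger inhibition. Compound 1, `C[C@@H](NC(=O)NCc1ccc(C(C)(C)C)cc1)c1ccc(NS(C)(=O)=O)cc1`, gives 680 nM. Compound 2, `C[C@@H](NC(=O)/C=C/c1ccc(C(C)(C)C)cc1)c1ccc(NS(C)(=O)=O)cc1`, gives 160 nM. Compound 3, `C/C(=C\c1ccc(C(C)(C)C)cc1)C(=O)N[C@H](C)c1ccc(NS(C)(=O)=O)cc1`, gives 46 nM, the lowest of the three numbers, and its gaps to compound 2 and to compound 1 both lie beyond the scatter. Compound 4, `C=Cc1cc([C@@H](C)NC(=O)/C(C)=C/c2ccc(C(C)(C)C)cc2)ccc1NS(C)(=O)=O`, is not yet measured; it differs from compound 3 by vinyl in place of hydrogen on an aromatic carbon. Among the compounds with values here, no measured pair shows this change, so its effect is unknown. A small step is expected, most likely within the scatter or a modest gain, written as a 1.3-fold lower number from compound 3 to compound 4 (0.12 log units; within the scatter). In this assay compound 4 is estimated at 35 nM, with a range from 12 nM to 110 nM.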

Compound 4, half-maximal inhibitory concentration: 22 nM
Estimate against measurement, compound 4: 1.6-fold (0.20 log units) above, within the range that was stated.
By their numbers in this assay, from the lowest: compound 4; then compound 3; then compound 2; then compound 1.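

Vinyl in place of hydrogen on this aromatic carbon, ortho to a methanesulfonamido group, gives the first measured step at this position: in this assay, a 2.1-fold lower number from compound 3 to compound 4 (0.32 log units; beyond the scatter). The position can therefore carry vinyl without loss, and the modest change lies beyond the scatter. Nothing available here gives a reason for this gain.

As far as these compounds go, it remains open whether ethyl, a methoxy group or an amine on this carbon would give a lower or higher number than vinyl. From the compounds shown here alone, it is also open whether vinyl would give a similar step on compound 2.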